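The source may report more compounds than this note shows. Statements on the series, on what has been measured and on what is new or still open speak of the compounds shown alone.

Working notes on a physicochemical assay for solubility, in phosphate buffer, at pH 7.4; on this read-out higher numbers stand for higher solubility and lower numbers for lower solubility: compound 2 (`CC(=O)N1CCC(c2cc3c(-c4ccc(=O)n(C(C)C)c4)ccnc3[nH]2)CC1`) gives 27000 nM, within the scatter of compound 1 (`CNC(=O)CN1CCC(c2cc3c(-c4ccc(=O)n(C(C)C)c4)ccnc3[nH]2)CC1`) at 34000 nM and of compound 3 (`COc1cc(F)ccc1-c1ccnc2[nH]c(C3CCN(CC(=O)N(C)C)CC3)cc12`) at 38000 nM. Compound 4 (`CC(C)n1cc(-c2ccnc3[nH]c(C4CCN(Cc5cccs5)CC4)cc23)ccc1=O`) is not yet measured. Its difference from compound 2 is (thiophen-2-yl)methyl in place of acetyl on an amine nitrogen in a ring. Among the measured compounds shown here, the only measured step at this nitrogen, a 1.3-fold lower number from compound 1 to compound 2 (0.10 log units; within the scatter), stays within the scatter, but no measured compound carries an aromatic ring there, so it is a weak guide. A step to a lower number, beyond the scatter, is expected in this assay, resting on the structural change alone. The expected size is a 3.4-fold lower number from compound 2 to compound 4 (0.53 log units; beyond the scatter). Compound 4 is estimated at 8000 nM, with an expected range of 1500 nM to 30000 nM.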

Compound 4, solubility: 25000 nM
Compound 4: middle estimate off by 3.1-fold (0.49 log units), on the low side, and the stated range covers the measured number.
By their numbers in this assay, from the lowest: compounds 4, 2, 1 and 3 (each within the scatter of the next).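

In this assay, (thiophen-2-yl)methyl brings a five-membered aromatic ring onto the amine nitrogen in a ring, and the step stays within the scatter (a 1.1-fold lower number from compound 2 to compound 4 (0.03 log units; within the scatter)). The same holds against the (methylcarbamoyl)methyl group (a 1.4-fold lower number from compound 1 to compound 4 (0.13 log units; within the scatter)), so compound 1, compound 2 and compound 4 show no step beyond the scatter at this nitrogen, with or without an aromatic ring. No supporting evidence bears on this result.

Still open, on these data alone, is whether this holds for a carboxylic acid, a primary amine or a longer chain on the same nitrogen.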